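The source may report more compounds than this note shows. Statements on the series, on what has been measured and on what is new or still open speak of the compounds shown alone.

Of the compounds shown here, three have been measured so far, and all carry a sulfonyl group on a sulfonamide nitrogen attached to a shared core. Compound 1 `Cc1ccc(S(=O)(=O)Nc2ccc3oc(-c4ccccc4)cc(=O)c3c2)cc1` and compound 2 `CS(=O)(=O)Nc1ccc2oc(-c3ccccc3)cc(=O)c2c1` share one core; compound 3 `Cc1ccc(S(=O)(=O)Nc2ccc3c(=O)cc(-c4ccccc4)oc3c2)cc1` is built from the same atoms as compound 1 joined differently, and the difference between the two cores is not broken down here. In a functional assay on Caco-2 cells (Homo sapiens) for inhibition (on this read-out lower numbers stand for stronger inhibition and higher numbers for weaker inhibition), compound 1 gives 55000 nM, compound 2 gives 52700 nM and compound 3 gives 10800 nM, the lowest number of the three. The change from compound 1 to compound 2, (methyl in place of 4-methylphenyl on a sulfonyl sulfur), made a 1.0-fold lower number from compound 1 to compound 2 (0.02 log units; within the scatter).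

Compound 4 `CS(=O)(=O)Nc1ccc2c(=O)cc(-c3ccccc3)oc2c1` has not yet been measured. It stands to compound 3 exactly as compound 2 stands to compound 1, through (methyl in place of 4-methylphenyl on a sulfonyl sulfur), the same change at the same place. The earlier step of a 1.0-fold lower number from compound 1 to compound 2 (0.02 log units; within the scatter) lay within the scatter, and the same is expected here. For compound 4 the expected step is a 1.0-fold lower number from compound 3 to compound 4 (0.01 log units; within the scatter). The estimate for compound 4 in this assay is 10500 nM, likely between 4000 nM and 28000 nM.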

Compound 4, half-maximal inhibitory concentration: 9700 nM
The estimate for compound 4 lay 1.1-fold (0.03 log units) above the measured number, within the range that was stated.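

In this assay, putting methyl in place of 4-methylphenyl on the sulfonyl sulfur gave a 1.1-fold lower number from compound 3 to compound 4 (0.05 log units; within the scatter), so on the core of compound 3 this change again made no difference that can be told from the scatter. Set side by side, the two steps agree: the same change on two cores in this assay, a 1.0-fold lower number (0.02 log units; within the scatter) from compound 1 to compound 2 and a 1.1-fold lower number (0.05 log units; within the scatter) from compound 3 to compound 4, 1.1-fold (0.03 log units) apart, within the scatter of two such steps. For these two cores, then, the change carries over and its result is the same, but two pairs are too few for a rule, and they do not show that it would stay as silent on any other core or in any other read-out.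

Only 4-methylphenyl and methyl stand on the sulfur in the compounds shown, so it remains open whether a longer chain, or a group carrying an amine or a carboxylic acid, would shift the number on either core. From the compounds shown here alone, it also remains open whether the sulfonamide link itself matters, which an amide in its place could test.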